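Nitro in Place of Cyano: Expected Potency of Compound 4

The compounds below may be only part of what the source reports. "The series", "measured", "known", "first", "only" and "open" are said of these compounds alone.

Measured so far:
compound 1, `N#Cc1ccc2c(c1)[C@@H](n1ccccc1=O)[C@H](O)C(CF)(CF)O2`, in a functional assay (aorta) with Rattus norvegicus as the target (a higher number here means that more compound is needed for the effect, a lower number that less compound is needed), gives 148 nM;
compound 2, `O=c1ccccn1[C@@H]1c2cc([N+](=O)[O-])ccc2OC(CF)(CF)[C@H]1O`, gives 28.8 nM;
compound 3, `N#Cc1ccc2c(c1)C(c1cccc[n+]1[O-])=CC(CF)(CF)O2`, gives 16.6 nM.

Compound 1 and compound 2 differ in a single place: nitro in place of cyano on an aromatic carbon. That change brought a 5.1-fold lower number from compound 1 to compound 2 (0.71 log units; beyond the scatter). Compound 3 has a different core from compound 1; the difference between the two cores is not broken down here. Compound 4, `O=[N+]([O-])c1ccc2c(c1)C(c1cccc[n+]1[O-])=CC(CF)(CF)O2`, is not yet measured. It differs from compound 3 by the same change at the same place: nitro in place of cyano on an aromatic carbon. The expectation for compound 4 rests on one earlier example, the step of a 5.1-fold lower number from compound 1 to compound 2 (0.71 log units; beyond the scatter), and since a single example is a thin basis, a somewhat smaller step is expected: a 3.7-fold lower number from compound 3 to compound 4 (0.57 log units; beyond the scatter). Compound 4 is therefore estimated to give about 4.5 nM, most likely between 1.5 nM and 14 nM.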

Compound 4, half-maximal effective concentration: 1.74 nM
Compound 4: the middle estimate sits 2.6-fold (0.41 log units) above what was measured, within the range that was stated.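

In this assay, nitro in place of cyano on an aromatic carbon brought a 9.5-fold lower number from compound 3 to compound 4 (0.98 log units; beyond the scatter), so the number fell on this second core too. The two steps point the same way and do not differ in size beyond what repeated measurement would give: the same change on two cores in this assay, a 5.1-fold lower number (0.71 log units; beyond the scatter) from compound 1 to compound 2 and a 9.5-fold lower number (0.98 log units; beyond the scatter) from compound 3 to compound 4, 1.9-fold (0.27 log units) apart, within the scatter of two such steps. This supports carrying the change between these two cores, but two pairs in one assay cannot show that it holds on every core in the series, nor why it lowers the number.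

Only cyano and nitro appear at this aromatic carbon among the compounds shown. Going by these compounds, how another group there, such as an amine or a carboxylic acid, would compare remains open.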